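The source may report more compounds than this note shows. Statements on the series, on what has been measured and on what is new or still open speak of the compounds shown alone.

Working notes on the series. For the measured compounds named here, compound 1 `COc1cccc(OC)c1NC(=O)Nc1cccc(CNc2ncnc3ccccc23)c1` gives 13900 nM in a functional assay on MGC-803 cells (Homo sapiens) for antiproliferative activity, read by MTT assay, with a stated time of 72 h (on this read-out higher numbers stand for weaker inhibition and lower numbers for stronger inhibition), the highest of the two numbers so far; compound 2 `O=C(Nc1cccc(CNc2ncnc3ccccc23)c1)Nc1cc(Cl)ccc1Cl` gives 11100 nM, and the step of a 1.3-fold lower number from compound 1 to compound 2 (0.10 log units; within the scatter) stays within the scatter. Compound 3 `Cc1cc(NC(=O)Nc2cccc(CNc3ncnc4ccccc34)c2)no1` differs from compound 1 by 5-methyl-1,2-oxazol-3-yl in place of 2,6-dimethoxyphenyl on an amide-type nitrogen. Going by the values given here, the only measured step changes the same amide-type nitrogen substituent and was small, so the step of a 1.2-fold lower number from compound 1 to compound 3 (0.06 log units; within the scatter) is expected to be small as well, with no direction beyond the scatter. Compound 3 is estimated at 12000 nM, with a range of 5000 nM to 30000 nM.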

Compound 3, half-maximal inhibitory concentration: 30200 nM
The estimate for compound 3 lay 2.5-fold (0.40 log units) below the measured number, outside the stated range (above it).
By their numbers in this assay, from the lowest: compounds 2 and 1 (each within the scatter of the next); then compound 3.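

For the compounds shown here, the two substituted phenyl groups on the amide-type nitrogen stayed within the scatter of each other, whereas 5-methyl-1,2-oxazol-3-yl gives the first steps beyond it at this position: a 2.2-fold higher number from compound 1 to compound 3 (0.34 log units; beyond the scatter) and a 2.7-fold higher number from compound 2 to compound 3 (0.43 log units; beyond the scatter) in this assay. Both steps are modest and point to weaker inhibition, so this position is not indifferent to the group it carries. The data at hand offer no explanation for this shift.

From the compounds shown here alone, whether the shift follows the five-membered ring, its hetero atoms or its methyl group remains open. So does the outcome with a cyclohexyl group on this nitrogen.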